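This account rests on a few compounds, and the source may have more. Where it says the series, first, only, none or still open, it means among the compounds named here.

Measured so far:
- compound 1, `c1ccc(CN(CCCCN(C[C@H]2Cc3ccccc3CN2)[C@H]2CCCc3cccnc32)Cc2ccccc2)cc1`: > 30000 nM
- compound 2, `c1ccc2c(c1)CN[C@@H](CN(CCCCNCC1CCNCC1)[C@H]1CCCc3cccnc31)C2`: > 30000 nM
- compound 3, `c1ccc2c(c1)CN[C@@H](CN(Cc1ccc(CNC3CCOCC3)cc1)[C@H]1CCCc3cccnc31)C2`: > 30000 nM

The three measured compounds share a core and were tested in a functional assay on cells for agonist activity at C-X-C chemokine receptor type 4 (Homo sapiens), read by fluorescence and calcium flux, with a stated time of 90 s; on this read-out lower numbers stand for an effect already at smaller amounts and higher numbers for an effect only at larger amounts of compound. For compound 1 the result is only a limit, > 30000 nM. For compound 2 the result is likewise only a limit, > 30000 nM. For compound 3 the result is again a limit, > 30000 nM. So compound 2 stands where every measured compound stands: at the limit, with no number to compare, as summed up in the limit of > 30000 nM in this assay, at which 3 of the 3 values shown sit.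

Compound 4, `C(=C/CN(C[C@H]1Cc2ccccc2CN1)[C@H]1CCCc2cccnc21)\CNCc1cccnc1`, has not yet been tested in this assay. Compared with compound 2, the change is a group of 11 heavy atoms (9 carbon, 2 nitrogen; one six-membered aromatic ring with 1 hetero atom) in place of a group of 11 heavy atoms (9 carbon, 2 nitrogen; one six-membered non-aromatic ring with 1 hetero atom), on a saturated chain carbon bound to an amine nitrogen.

For the measured compounds named here, no pair of measured compounds differs in a single place, so no measured step shows what such a change does. All three measured results sit at the same limit, which gives no footing for expecting a turn toward an effect at smaller amounts. The step expected from compound 2 to compound 4 in this assay is therefore a number no higher from compound 2 to compound 4 (the limit leaves the size open), that is, no change beyond the scatter. Compound 4 is expected to give about 30000 nM in this assay, within a range from 10000 nM to 100000 nM, and most likely to be reported again only as a limit.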

Compound 4, half-maximal effective concentration: > 30000 nM
Compound 4: no number, only a limit; the forecaster's own chance of this, stated with the estimate: 75%; the middle value lies on the limit itself.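

In this assay compound 4 gives > 30000 nM, again only a limit. Compound 2 also has only a limit, so no step can be read between compound 2 and compound 4, and the overall picture stays the same: the limit of > 30000 nM in this assay, at which 4 of the 4 values shown sit.

These compounds leave open whether the aromatic ring entering in compound 4 differs at all from the non-aromatic ring of compound 2, and which change to the shared core would give a measurable effect.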